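Arylsulfonyl quinoline series: liver microsome clearance notes

The source may hold more compounds than are shown below. What is called first, only, known or untested is meant among the compounds shown, and "the series" means these compounds.

Measured so far:
compound 1, `COc1ccc(-c2c(S(=O)(=O)c3ccc(C)c(F)c3)cnc3c(F)cccc23)cc1` — 3.27 mL/min
compound 2, `O=S(=O)(c1ccc(F)c(Cl)c1)c1cnc2c(F)cccc2c1-c1ccc(F)cc1` — 0.19 mL/min

In an ADME assay on microsomes from liver (Homo sapiens) for metabolic stability, tested at 2.5 uM (a higher number here means faster removal of the compound, a lower number slower removal), compound 1 gives 3.27 mL/min and compound 2 gives 0.19 mL/min. Compound 2 therefore holds the lower of the two numbers, and compound 1 the higher; the gap between them is beyond the usual scatter. For the measured compounds named here, no single-change step between measured compounds is available, as the two compounds differ in more than one place.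

Compound 3, `Cc1ccc(S(=O)(=O)c2cnc3c(F)cccc3c2-c2ccc(F)cc2)cc1F`, is the next compound to be run in this assay. It differs from compound 2 by 3-fluoro-4-methylphenyl in place of 3-chloro-4-fluorophenyl on a sulfonyl sulfur. The group that enters is the one carried on the sulfonyl sulfur of compound 1, while the remaining portion of compound 3 matches compound 2.

Going by the values given here, with no measured step of this kind to lean on, the expectation for compound 3 rests on the two values in hand. Compound 3 is estimated at 0.6 mL/min, within a range of 0.2 mL/min to 1.8 mL/min. This estimate means a step from compound 2 to compound 3 of a 3.2-fold higher number from compound 2 to compound 3 (0.50 log units; beyond the scatter), an upward shift of moderate size, expected because compound 1 gives 3.27 mL/min with the same group on the sulfonyl sulfur.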

Compound 3, intrinsic clearance in a liver preparation (reported as CLH), per the amount of preparation that the assay uses: 2.75 mL/min
The estimate for compound 3 lay 4.6-fold (0.66 log units) below the measured number, outside the stated range (above it).
By their numbers in this assay, from the lowest: compound 2; then compounds 3 and 1 (each within the scatter of the next).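

In this assay, the group on the sulfonyl sulfur proves to be a sensitive position: 3-fluoro-4-methylphenyl in place of 3-chloro-4-fluorophenyl gives a large step (a 14-fold higher number from compound 2 to compound 3 (1.16 log units; beyond the scatter)). The other single change now available, fluoro in place of methoxy on an aromatic carbon, stays within the scatter (a 1.2-fold lower number from compound 1 to compound 3 (0.08 log units; within the scatter)). Within these three compounds, the change on the sulfonyl sulfur therefore moves the number beyond the scatter, while the change on the aromatic carbon does not, though each change is seen only once. Nothing measured here explains why the exchange on the sulfonyl sulfur has this effect.

From the compounds shown here alone, the two groups on the sulfonyl sulfur differ in more than one atom, so it remains open which part of the exchange carries the step, and whether it would hold with another group on the aromatic carbon. Also open, going by these compounds, is how this assay would read with a piperidine amine or a carboxylic acid on the sulfonyl sulfur or the aromatic carbon.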